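Swapping the amine substituent: from chloromethylphenyl to fluorobenzyl

The source may hold more compounds than are shown below. What is called first, only, known or untested is meant among the compounds shown, and "the series" means these compounds.

Three compounds built on one shared core were tested in an assay on COS-7 cells for agonist activity at Free fatty acid receptor 1 (Homo sapiens), read by scintillation counting and inositol phosphate accumulation, with a stated time of 90 min; a lower number here means that less compound is needed, a higher number that more compound is needed for the effect. In this assay compound 1 `Cc1cc(=O)oc2cc(OCc3nc(N)nc(Nc4ccc(Cl)cc4)n3)ccc12` gives 32500 nM, compound 2 `Cc1cc(=O)oc2cc(OCc3nc(N)nc(Nc4ccc5c(c4)COC5)n3)ccc12` gives 1330 nM, and compound 3 `Cc1cc(Nc2nc(N)nc(COc3ccc4c(C)cc(=O)oc4c3)n2)ccc1Cl` gives 240 nM. Compound 3 stands lowest of the three: its nearest neighbour is reached by the step of a 5.5-fold lower number from compound 2 to compound 3 (0.74 log units; beyond the scatter), and its furthest by the step of a 140-fold lower number from compound 1 to compound 3 (2.13 log units; beyond the scatter).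

Compound 4 `Cc1cc(=O)oc2cc(OCc3nc(N)nc(NCc4ccc(F)cc4)n3)ccc12` differs from compound 3 in one place: 4-fluorobenzyl in place of 4-chloro-3-methylphenyl on a nitrogen on an aromatic ring. Among the measured compounds shown here, two measured steps bear on this change. The step of a 140-fold lower number from compound 1 to compound 3 (2.13 log units; beyond the scatter) shows how much the methyl on the aromatic ring is worth, and compound 4 has no such methyl. The step of a 5.5-fold lower number from compound 2 to compound 3 (0.74 log units; beyond the scatter) shows that the chloromethylphenyl ring of compound 3 outperforms a different aromatic group on the same nitrogen. As far as these compounds go, compound 4 also trades chlorine for fluorine and inserts a benzyl carbon between ring and nitrogen; neither of these has a measured parallel among the three compounds, so their effect is unknown. On balance a large rise in this assay is expected, estimated as a 63-fold higher number from compound 3 to compound 4 (1.80 log units; beyond the scatter). Compound 4 is therefore expected to give about 15000 nM, in a range from 3000 nM to 60000 nM.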

Compound 4, half-maximal effective concentration: 7820 nM
The estimate for compound 4 lay 1.9-fold (0.28 log units) above the measured number, within the range that was stated.
By their numbers in this assay, from the lowest: compound 3; then compound 2; then compound 4; then compound 1.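

In this assay the step to 4-fluorobenzyl on this nitrogen is a large loss against the best group shown (a 33-fold higher number from compound 3 to compound 4 (1.51 log units; beyond the scatter)), so a group of the same heavy-atom count does not keep the effect of 4-chloro-3-methylphenyl. It is not the poorest group at this position, though: 4-fluorobenzyl improves on 4-chlorophenyl (a 4.2-fold lower number from compound 1 to compound 4 (0.62 log units; beyond the scatter)) yet falls short of the group with the five-membered non-aromatic ring (a 5.9-fold higher number from compound 2 to compound 4 (0.77 log units; beyond the scatter)), which places compound 4 third of the four and shows that a ring set one carbon away from the nitrogen can still give a measurable effect. No measurement is available that would explain this order.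

As far as these compounds go, the change in compound 4 ties two differences together, the extra carbon and fluorine for chlorine, so the share of each in these steps stays unknown. A 4-fluorophenyl or a 4-chlorobenzyl group on the same nitrogen would separate the two, and a 4-chloro-3-methylbenzyl group would show whether the methyl still counts once that carbon is present.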